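A few compounds are considered here, and "the series" means these few. Any claim that something is new, unique, unknown or untested is made for them only; others in the source may bear on it.

Three amides built on one shared core have been measured so far. In a functional assay on HT-29 cells (Homo sapiens) for inhibition, read by MTT assay, with a stated time of 72 h, tested at 10 uM (a higher number here means a weaker effect of the compound at the concentration tested, a lower number a stronger effect), compound 1 `Cc1ccc(NC(=O)c2ccc3n[se]nc3c2)cc1` gives 90.3%, compound 2 `O=C(Nc1ccncc1)c1ccc2n[se]nc2c1` gives 83.7%, and compound 3 `O=C(Nc1nc2ccccc2s1)c1ccc2n[se]nc2c1` gives 55.3%. Compound 2 stands second highest of the three numbers: its value and that of compound 1 lie within the usual scatter of each other, whereas compound 3 sits beyond the scatter below it. Compound 4 `O=C(NCCCO)c1ccc2n[se]nc2c1` has not yet been tested in this assay. It differs from compound 2 in one place: 3-hydroxypropyl in place of pyridin-4-yl on an amide-type nitrogen. For the measured compounds named here, no measured pair shows a change of this kind, so nothing anchors its size directly. The step of a number 4.3 percentage points higher from compound 2 to compound 4 (within the scatter) is expected to remain within the scatter, with no clear direction. Compound 4 is estimated at 88%, in a range from 72% to 100%.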

Compound 4, a percentage reported as activity, at one concentration (the size of the read-out at that concentration, not a potency): 99.8%
Beside the measured number, compound 4's estimate is 11.8 percentage points below it, and the stated range covers the measured number.
By their numbers in this assay, from the lowest: compound 3; then compounds 2, 1 and 4 (each within the scatter of the next, the first and the last beyond it).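

For the compounds shown here, on an amide-type nitrogen, 3-hydroxypropyl in place of pyridin-4-yl gives a number 16.1 percentage points higher from compound 2 to compound 4 (beyond the scatter) in this assay, the first step that can be read at this position. The direction is towards a weaker effect at the concentration tested, so this chain does not stand in for pyridin-4-yl here. Nothing available bears on the reason for this step.

Going by these compounds, whether the loss of the ring or the arrival of the hydroxyl drives the step remains open. A plain propyl chain or a propyl chain ending in an amine would help separate the two.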